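This account rests on a few compounds, and the source may have more. Where it says the series, first, only, none or still open, it means among the compounds named here.

Working notes on the shared core of compound 1 `COc1ccc([C@H]2CC(=O)N(Cc3cccc([N+](=O)[O-])c3)C2)cc1OC1CCCC1`, a pyrrolidinone series screened in a functional assay on HEK293 cells (Homo sapiens) for cytotoxicity; a higher number here means that more compound is tolerated, a lower number that less compound is tolerated.

Three members have been run so far. Compound 1 returns only a limit of the assay in this assay, > 10000 nM. Compound 2 `COc1ccc([C@H]2CC(=O)N(c3ccc(N)cc3)C2)cc1OC1CCCC1` likewise returns only a limit, > 10000 nM. Compound 3 `COc1ccc([C@H]2CC(=O)N(c3ccccc3C#N)C2)cc1OC1CCCC1` also sits at a limit, > 10000 nM. Every value in hand is therefore a limit and not a number, and the limit of > 10000 nM in this assay, at which 3 of the 3 values shown sit, summarises the whole set.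

The three steps between them give nothing to read: a step that the two limits leave unreadable from compound 1 to compound 2, a step that the two limits leave unreadable from compound 1 to compound 3 and a step that the two limits leave unreadable from compound 2 to compound 3 are each left unreadable by the two limits. Compound 2 thus stands at the limit alongside the other two, with no ordering possible among them.

The next compound, compound 4 `COc1ccc([C@H]2CC(=O)N(c3ccc(C(F)(F)F)cc3)C2)cc1OC1CCCC1`, differs from compound 2 by trifluoromethyl in place of amino on an aromatic carbon. Among the measured compounds shown here, no measured step in this assay resolves the effect of a substituent swap on this ring, so there is no measured basis for expecting a step beyond the scatter in either direction; the working expectation is that compound 4 also remains at the limit in this assay.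

Estimate for compound 4: 15000 nM, with a range from 5000 nM to 50000 nM, meaning an expected step that the limit leaves unreadable from compound 2 to compound 4.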

Compound 4, half-maximal cytotoxic concentration: > 10000 nM
Compound 4: no number, only a limit; the forecaster's own chance of this, stated with the estimate: 80%; the middle value is on the limit's open side.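

Compound 4 also returns only a limit of the assay, > 10000 nM, so its steps from compound 1, compound 2 and compound 3 cannot be read. The compounds shown leave open whether any group on the shared core gives a number in this assay, and how such groups would rank, as the whole set stands at one limit: the limit of > 10000 nM in this assay, at which 4 of the 4 values shown sit.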